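Chlorine pattern on the aryl amine and inhibitory potency

The source may report more compounds than this note shows. Statements on the series, on what has been measured and on what is new or still open speak of the compounds shown alone.

Compound 2 `Cc1cc(NC(=O)Nc2ccc(Cl)cc2)ccc1OCc1nc2ccccc2s1` reaches only the assay limit in an assay on isolated protein for inhibition of Polyunsaturated fatty acid 5-lipoxygenase (Homo sapiens), read by HPLC, with a stated time of 10 min (on this read-out lower numbers stand for stronger inhibition and higher numbers for weaker inhibition), recorded as > 10000 nM. Compound 1 `Cc1cc(NC(=O)Nc2cccc(Cl)c2)ccc1OCc1nc2ccccc2s1` gives 2090 nM in this assay, and the step of an at least 4.7-fold higher number from compound 1 to compound 2 (0.67 log units; beyond the scatter) therefore runs into the limit (the limit of > 10000 nM in this assay, at which 1 of the 2 values shown sits). Compound 3 `Cc1cc(NC(=O)Nc2cc(Cl)cc(Cl)c2)ccc1OCc1nc2ccccc2s1` differs from compound 2 by 3,5-dichlorophenyl in place of 4-chlorophenyl on an amide-type nitrogen. For the measured compounds named here, the single measured step, 3-chlorophenyl to 4-chlorophenyl, weakened inhibition beyond the scatter; reversing that direction and adding a further chlorine is expected to lower the number for compound 3 by an at least 6.6-fold lower number from compound 2 to compound 3 (0.82 log units; beyond the scatter). Compound 3 is thus estimated at 1500 nM, within 400 nM to 8000 nM.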

Compound 3, half-maximal inhibitory concentration: 720 nM
The estimate for compound 3 lay 2.1-fold (0.32 log units) above the measured number, and the stated range covers the measured number.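

With the 3-chlorophenyl group kept, chloro in place of hydrogen on an aromatic carbon gives a 2.9-fold lower number from compound 1 to compound 3 (0.46 log units; beyond the scatter), so a further chlorine on this aryl group lowers the number, unlike the change to 4-chlorophenyl. Replacing 4-chlorophenyl with 3,5-dichlorophenyl gives an at least 13-fold lower number from compound 2 to compound 3 (1.14 log units; beyond the scatter). Compound 2 stands only at a limit, so the full size of that step stays unknown: the limit of > 10000 nM in this assay, at which 1 of the 3 values shown sits.

As far as these compounds go, whether this gain requires chlorine stays open. A methyl, methoxy or trifluoromethyl group in place of chlorine on this aryl group, or a plain phenyl, would address that.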